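Compound 4: dimethylamino in place of methoxy

The compounds below may be only part of what the source reports. "The series", "measured", "known", "first", "only" and "open" are said of these compounds alone.

Compound 2 `COc1ccc(C2CC(c3ccccc3)=NN2C2=NC(=O)/C(=C3\C(=O)Nc4ccc(Br)cc43)S2)cc1` gives 180 nM in a functional assay on cells (Cancer cell lines, Homo sapiens) for cytotoxicity, read by sulforhodamine B assay, with a stated time of 48 h (on this read-out higher numbers stand for weaker inhibition of growth and lower numbers for stronger inhibition of growth), and stands second highest of the three numbers. Compound 1 `COc1ccc(C2CC(c3ccccc3)=NN2C2=NC(=O)/C(=C3\C(=O)Nc4ccccc43)S2)cc1` gives 2010 nM; the step of an 11-fold lower number from compound 1 to compound 2 (1.05 log units; beyond the scatter) goes with bromo in place of hydrogen on an aromatic carbon. Compound 3 `COc1ccc(C2CC(c3ccc4ccccc4c3)=NN2C2=NC(=O)/C(=C3\C(=O)Nc4ccc(Br)cc43)S2)cc1` gives 64 nM; the step of a 2.8-fold lower number from compound 2 to compound 3 (0.45 log units; beyond the scatter) goes with naphthalen-2-yl in place of phenyl on a carbon with a double bond to nitrogen.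

Compound 4 `CN(C)c1ccc(C2CC(c3ccccc3)=NN2C2=NC(=O)/C(=C3\C(=O)Nc4ccc(Br)cc43)S2)cc1` differs from compound 2 by dimethylamino in place of methoxy on an aromatic carbon. For the measured compounds named here, neither measured step bears directly on this part of the shared core: the bromo step and the naphthalen-2-yl step both sit on other rings, so the series gives no precedent for exchanging the methoxy group. In the absence of any measured change at this ring, the step in this assay is expected to be no change at the digits printed from compound 2 to compound 4 (within the scatter), that is none beyond the scatter. Compound 4 is accordingly estimated at 180 nM in this assay, with a range from 80 nM to 400 nM.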

Compound 4, concentration for 50% growth inhibition: 200 nM
Compound 4: the middle estimate sits 1.1-fold (0.05 log units) below what was measured; low and high end bracket the measured number.
By their numbers in this assay, from the lowest: compound 3; then compounds 2 and 4 (each within the scatter of the next); then compound 1.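

The 4-methoxyphenyl to 4-(dimethylamino)phenyl exchange is the first change shown at this ring, para to a large group, and in this assay it reads as a 1.1-fold higher number from compound 2 to compound 4 (0.05 log units; within the scatter). Compounds 2 and 4 therefore cannot be told apart, so dimethylamino is accepted in place of methoxy at this position with the rest of compound 2 unchanged. This contrasts with the two earlier steps on other rings, an 11-fold lower number from compound 1 to compound 2 (1.05 log units; beyond the scatter) and a 2.8-fold lower number from compound 2 to compound 3 (0.45 log units; beyond the scatter), both beyond the scatter. No measurement available here accounts for the two groups reading alike.

Still open, as far as these compounds go, is how this position responds to a primary amine, a hydroxyl, a carboxylic acid or a longer alkoxy chain. Also open, from the compounds shown here alone, is whether the same exchange reads alike with naphthalen-2-yl in place of phenyl, as in compound 3.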